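The compounds below may be only part of what the source reports. "The series", "measured", "known", "first", "only" and "open" are said of these compounds alone.

Compound 1 `Cc1c(O)c(C)c2c(c1O)C(=O)CC(c1cccc(O)c1)O2`: "not active" (no number reported)
Compound 2 `Cc1c(O)c(C)c2c(c1O)C(=O)CC(c1ccc(Cl)cc1)O2`: "not active" (no number reported)
Compound 3 `Cc1c(O)c(C)c2c(c1O)C(=O)CC(c1ccccc1Cl)O2`: > 20000 nM

None of these three compounds gives an exact potency in a functional assay on VSMC cells (Rattus norvegicus); on this read-out lower numbers stand for stronger inhibition and higher numbers for weaker inhibition. Compound 3 stands at > 20000 nM, which is a limit of the assay and not a number. This leaves the limit of > 20000 nM in this assay, at which 1 of the 3 values shown sits, as the only numerical reference point.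

Compound 4 `Cc1c(O)c(C)c2c(c1O)C(=O)CC(c1ccco1)O2` has furan-2-yl in place of the 2-chlorophenyl of compound 3 on a saturated ring carbon, next to the ring oxygen: furan-2-yl in place of 2-chlorophenyl on a saturated ring carbon. Among the measured compounds shown here, no measured pair shows what such a change does. In this assay, no shift beyond the usual scatter is expected in either direction, and the estimated change is a step that the limit leaves unreadable from compound 3 to compound 4. Compound 4 is estimated at 25000 nM, with an expected range from 10000 nM to 60000 nM.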

Compound 4, half-maximal inhibitory concentration: 6700 nM
The estimate for compound 4 lay 3.7-fold (0.57 log units) above the measured number; the whole stated range lies above it.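

In this assay, furan-2-yl in place of 2-chlorophenyl on this saturated ring carbon, next to the ring oxygen, gives an at least 2.9-fold lower number from compound 3 to compound 4 (0.47 log units; beyond the scatter). Among the compounds shown here, this is the first sign that the group at this position can shift the read-out, and compound 4 supplies the first exact number. The true size of the step stays unknown because one end of it is a limit: the limit of > 20000 nM in this assay, at which 1 of the 4 values shown sits.

Steps involving compounds 1 and 2 cannot be read. Going by these compounds, it also remains open how a thiophen-2-yl ring, or a phenyl ring carrying an amine or a carboxylic acid, would behave at this position.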